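The source may report more compounds than this note shows. Statements on the series, on what has been measured and on what is new or still open speak of the compounds shown alone.

Measured so far in a functional assay on SF-295 cells (Homo sapiens) for inhibition, read by sulforhodamine B assay, with a stated time of 48 h; a lower number here means a stronger inhibitor of growth, a higher number a weaker inhibitor of growth:
compound 1 `COc1cc(-c2nn(-c3cccc(NC(=O)Nc4ccc(Cl)c(Cl)c4)c3)cc2-c2ccncc2)ccc1Cl`, 2530 nM
compound 2 `COc1cc(-c2nn(-c3cccc(NC(=O)Nc4cccc(C(F)(F)F)c4)c3)cc2-c2ccncc2)ccc1Cl`, 1130 nM

Compound 2 has the lowest of the two numbers in this assay; the nearest is compound 1, where a 2.2-fold lower number from compound 1 to compound 2 (0.35 log units; beyond the scatter). Compound 3 `COc1cc(-c2nn(-c3cccc(NC(=O)c4ccc(Cl)c(C(F)(F)F)c4)c3)cc2-c2ccncc2)ccc1Cl` differs from compound 2 by 4-chloro-3-(trifluoromethyl)phenyl in place of (3-(trifluoromethyl)phenyl)amino on a carbonyl carbon. Among the compounds with values here, the only measured step, from compound 1 to compound 2, changes the aryl group on the amide-type nitrogen while keeping the carbonyl link intact, so it bears on the present change only loosely; its size was modest. Within the data shown here, no measured pair shows what removing the amino link from the carbonyl does, so the expectation for this assay is a step of no clear direction, probably within or just beyond the scatter. The estimate for compound 3 is therefore 1500 nM, with a range from 500 nM to 4500 nM, meaning an expected step of a 1.3-fold higher number from compound 2 to compound 3 (0.12 log units; within the scatter).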

Compound 3, concentration for total growth inhibition: 17300 nM
For compound 3 the middle estimate is 12-fold (1.06 log units) below the measured one; the measured number lies above the stated range.
By their numbers in this assay, from the lowest: compound 2; then compound 1; then compound 3.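

In this assay the carbonyl carbon responds far more strongly to losing its amino link than the amide-type nitrogen did to an exchange of aryl groups, with a 15-fold higher number from compound 2 to compound 3 (1.18 log units; beyond the scatter) against a 2.2-fold lower number from compound 1 to compound 2 (0.35 log units; beyond the scatter) for that earlier exchange. The same direction appears with a 6.8-fold higher number from compound 1 to compound 3 (0.83 log units; beyond the scatter) and so both compounds that keep the amino link give lower numbers than compound 3, each step beyond the scatter. Nothing measured on these compounds accounts for the loss.

On these data alone, the step removes the amino link and adds the 4-chloro substituent together, so the share of each remains open. A (4-chloro-3-(trifluoromethyl)phenyl)amino group on the same carbonyl carbon would separate the two, and a methylene link in place of the amino link would show whether the amide hydrogen matters.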